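Same Aryl Swap on Two Cores, Measured Once, Expected Twice

The compounds below may be only part of what the source reports. "The series", "measured", "known", "first", "only" and "open" are said of these compounds alone.

Three compounds have so far been measured in an in vitro functional assay on HEK293 cells for antagonist activity at melanin-concentrating hormone receptor 1 (Homo sapiens); on this read-out higher numbers stand for larger maximal responses and lower numbers for smaller maximal responses:

Compound 1, `Cc1ccc(CN2CCC(NC(=O)NCc3ccc(-c4ccc(F)cc4)cc3)CC2)cc1`, gives 105%.
Compound 2, `Cc1ccc(CN2CCC(NC(=O)NCc3ccc(-c4cccc(C#N)c4)cc3)CC2)cc1`, gives 98%.
Compound 3, `Cc1ccc(CN2CCC(CCN(Cc3ccc(-c4ccc(F)cc4)cc3)C(=O)NC(C)(C)CO)CC2)cc1`, gives 102%.

Compound 1 and compound 2 share a core and differ in one place only: 3-cyanophenyl in place of 4-fluorophenyl on an aromatic carbon. In this assay this change gave a number 7 percentage points lower from compound 1 to compound 2 (within the scatter), a step that lies within the usual scatter of the method, so the two compounds cannot be told apart on this read-out.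

Compound 3 is built on a different core. How its core differs from the core of compound 1 is not broken down here. What the values show is that compound 3 and compound 1, and likewise compound 3 and compound 2, all lie within the scatter of one another in this assay.

Compound 4, `Cc1ccc(CN2CCC(CCN(Cc3ccc(-c4cccc(C#N)c4)cc3)C(=O)NC(C)(C)CO)CC2)cc1`, has not yet been measured. It stands to compound 3 exactly as compound 2 stands to compound 1: 3-cyanophenyl in place of 4-fluorophenyl on an aromatic carbon. The place is described in the same words for both pairs, so this is the same change, now made on the second core.

Compound 4 is therefore expected to give 96% in this assay, with an expected range from 85% to 107%. This estimate means an expected step of a number 6 percentage points lower from compound 3 to compound 4 (within the scatter), of about the same size as the measured one, and it rests on compound 1 and compound 2, where the same change gave a number 7 percentage points lower from compound 1 to compound 2 (within the scatter).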

Compound 4, largest response reached (reported as Imax), in percent of the reference or control that the assay uses: 99.3%
Estimate against measurement, compound 4: 3.3 percentage points below, and the stated range covers the measured number.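

On the second core, in this assay, placing 3-cyanophenyl where 4-fluorophenyl stood gave a number 2.7 percentage points lower from compound 3 to compound 4 (within the scatter). Set beside the step on the first core, this step cannot be told apart from it, so the change behaved alike on the two cores as far as this read-out can tell: the same change on two cores in this assay, a number 7 percentage points lower (within the scatter) from compound 1 to compound 2 and a number 2.7 percentage points lower (within the scatter) from compound 3 to compound 4, 4.3 percentage points apart, within the scatter of two such steps. Within the data shown here, this agreement is a modest finding, though: neither step can be separated from the scatter, so the data show only that the swap produced no readable step on either core, not that a shift of a given size carries over from one core to the other, and two cores cannot speak for the whole series.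

The compounds shown leave open what happens with a group of a different kind at this place, such as an amine or a carboxylic acid in place of the nitrile, and whether either would give a step beyond the scatter. If such a group did, comparing that step on both cores would be a far sharper test of whether a change made on one core can be relied on for the other.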